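Benzamido for azido on the chain carbon of compound 3

The compounds below may be only part of what the source reports. "The series", "measured", "known", "first", "only" and "open" are said of these compounds alone.

In a functional assay on MCF7 cells (Homo sapiens) for cytotoxicity, read by MTT assay, with a stated time of 72 h (on this read-out lower numbers stand for stronger inhibition and higher numbers for weaker inhibition), compound 1 `NS(=O)(=O)c1cc(-c2nnc(CN3CCN(c4ccc(F)cc4)CC3)o2)c(Cl)cc1SCc1ccccc1` gives 240000 nM. Within the data shown here, compound 2 `Cc1ccc(C)c(N2CCN(Cc3nnc(-c4cc(S(N)(=O)=O)c(SCc5ccccc5)cc4Cl)o3)CC2)c1` gives 51000 nM in this assay, and the single comparable step in the set is a 4.7-fold lower number from compound 1 to compound 2 (0.67 log units; beyond the scatter). Compound 3 `[N-]=[N+]=NCc1nnc(-c2cc(S(N)(=O)=O)c(SCc3ccccc3)cc2Cl)o1` gives 55000 nM in this assay, the second highest of the three numbers: its gap to compound 2 lies within the scatter, so no order is claimed between those two, whereas against compound 1 the gap is beyond the scatter and compound 3 carries the lower number.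

Compound 4 `NS(=O)(=O)c1cc(-c2nnc(CNC(=O)c3ccccc3)o2)c(Cl)cc1SCc1ccccc1` differs from compound 3 by benzamido in place of azido on a saturated chain carbon bound to an aromatic carbon. Among the measured compounds shown here, the one measured step concerns the aryl group on an amine nitrogen in a ring, a different part of the shared core, and says nothing direct about a substitution on the saturated chain carbon bound to an aromatic carbon; beyond that, all three measured numbers sit in a narrow, weak band. A step of uncertain direction is therefore expected, most likely not beyond the scatter, with the higher end of the band as the main risk. For compound 4 the expected value in this assay is 60000 nM, within a range from 20000 nM to 200000 nM. This corresponds to an expected 1.1-fold higher number from compound 3 to compound 4 (0.04 log units; within the scatter).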

Compound 4, half-maximal inhibitory concentration: 66000 nM
Compound 4: middle estimate off by 1.1-fold (0.04 log units), on the low side; measured number inside the range.
By their numbers in this assay, from the lowest: compounds 2, 3 and 4 (each within the scatter of the next); then compound 1.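

In this assay, among these compounds, the move from azido to benzamido on a saturated chain carbon bound to an aromatic carbon is a 1.2-fold higher number from compound 3 to compound 4 (0.08 log units; within the scatter) and is the first step read at this position, as the only earlier step concerned the aryl group on an amine nitrogen in a ring. This position therefore accepts a group of 9 heavy atoms, with a six-membered aromatic ring and 1 hydrogen-bond donor, in place of one of 3 heavy atoms with no ring and no donor, and the number does not move beyond the scatter. For this pair, neither the larger group, nor the added ring, nor the amide hydrogen opens a readable gain or loss, and no supporting evidence bears on the result.

Still open, from the compounds shown here alone, is whether a primary amine or a carboxylic acid on the same chain carbon would separate from azido and benzamido in this assay in either direction. A longer chain in place of the azidomethyl and benzamidomethyl links, or a chloro or methoxy group on the ring of benzamido, is equally unresolved by the compounds shown.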